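Hydroxy to hydrogen: the step from compound 2

The compounds below may be only part of what the source reports. "The series", "measured", "known", "first", "only" and "open" are said of these compounds alone.

For the measured compounds named here, in an ADME assay on L929 cells (Mus musculus) for cytotoxicity, read by resazurin assay, with a stated time of 72 h (on this read-out higher numbers stand for weaker inhibition and lower numbers for stronger inhibition), only two compounds on the shared core have a result so far. Compound 1 `O=C(/C=C/c1ccc2c(c1)B(O)OC2)c1ccc(C(F)(F)F)cc1` gives > 10 ug/mL as a limit and not a number. Compound 2 `O=C(/C=C/c1ccc2c(c1)B(O)OC2)c1ccccc1O` gives > 10 ug/mL as a limit too. Compound 2 therefore stands at the limit of > 10 ug/mL in this assay, at which 2 of the 2 values shown sit, without an exact number. The next case is compound 3 `O=C(/C=C/c1ccc2c(c1)B(O)OC2)c1ccccc1` and the change hydrogen in place of hydroxy on an aromatic carbon puts hydrogen in place of hydroxy on an aromatic carbon, ortho to a large group, so that 2-hydroxyphenyl becomes phenyl. No measured step sizes this change, so no step beyond the scatter is expected in this assay in either direction. That expectation rests on compound 2 at > 10 ug/mL as a limit. The estimated step runs a step that the limit leaves unreadable from compound 2 to compound 3 on this reading. For compound 3 the estimated value is 15 ug/mL with an expected range from 6 ug/mL to 40 ug/mL and a limit rather than a number is likely.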

Compound 3, half-maximal inhibitory concentration: > 10 ug/mL
Compound 3 gave a limit, no number; the forecaster's own chance of this, stated with the estimate: 75%; the middle value lies beyond the limit too.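

No step can be read from compound 1 or compound 2 to compound 3 in this assay, as all three are reported only as a limit: the limit of > 10 ug/mL in this assay, at which 3 of the 3 values shown sit.

The compounds shown leave open where each exact value lies, and whether hydroxy, trifluoromethyl or hydrogen makes any difference.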